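The source may report more compounds than this note shows. Statements on the series, on what has been measured and on what is new or still open speak of the compounds shown alone.

Compound 1 `Oc1ccc(-c2nc3ccccc3s2)cc1O` gives 15600 nM
Compound 2 `COc1ccc(-c2nc3ccccc3s2)cc1OC` gives 74200 nM
Compound 3 `COc1ccc(-c2nc3cc(F)ccc3s2)cc1` gives 24600 nM

All three values come from a functional assay on KM12 cells (Homo sapiens) for antiproliferative activity (a lower number here means a stronger inhibitor of growth, a higher number a weaker inhibitor of growth), and sit on the same shared core. Compound 3 at 24600 nM cannot be told apart from compound 1 at 15600 nM. The gap between those two values lies within the scatter. The number of compound 3 is clearly lower than that of compound 2 at 74200 nM, a gap beyond the scatter.

Compound 4 `COc1ccc(-c2nc3cc(F)ccc3s2)cc1F` keeps compound 3 intact except for one swap: fluoro in place of hydrogen on an aromatic carbon, ortho to a methoxy group and meta to a large group (fluoro in place of hydrogen on an aromatic carbon). Going by the values given here, no two measured compounds differ in only one place, so the data give no direct measure of such a swap. All three measured values are fairly weak and lie in a narrow band, so only a small change is expected, none beyond the scatter. The expected change is a 1.2-fold lower number from compound 3 to compound 4 (0.09 log units; within the scatter). For compound 4 the estimated value is 20000 nM, with an expected range of 5000 nM to 70000 nM.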

Compound 4, concentration for 50% growth inhibition: 20600 nM
For compound 4 the middle estimate is 1.0-fold (0.01 log units) below the measured one; low and high end bracket the measured number.
By their numbers in this assay, from the lowest: compounds 1, 4 and 3 (each within the scatter of the next); then compound 2.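

In this assay, going by these compounds alone, the pair formed by compound 3 and compound 4 is the first that differs in only one place, and it gives a direct reading of this swap: fluoro in place of hydrogen on an aromatic carbon, ortho to a methoxy group and meta to a large group, gives a 1.2-fold lower number from compound 3 to compound 4 (0.08 log units; within the scatter) and stays within the scatter. With compound 3 as the starting point, this position therefore takes a fluoro while the two numbers cannot be told apart. Nothing at hand explains this result.

From the compounds shown here alone, whether another group at this position, such as an amine, a carboxylic acid or a longer chain, would give a number as close to that of compound 3 remains open. So does whether the same swap would give a similar step on compound 1 or compound 2.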